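The compounds below may be only part of what the source reports. "The series", "measured", "known", "first", "only" and "open" are said of these compounds alone.

Going by the values given here, in a functional assay on MCF7 cells (Homo sapiens) for antiproliferative activity, read by sulforhodamine B assay, with a stated time of 48 h (on this read-out higher numbers stand for weaker inhibition of growth and lower numbers for stronger inhibition of growth), three compounds have numbers so far. Compound 1 `COc1ccc2cc(CCCSc3nnnn3-c3ccccc3)oc(=O)c2c1` gives 45.7 ug/mL in this assay. Compound 2 `O=C1OC(CO)Cc2ccccc21` gives 0.66 ug/mL in this assay. Compound 3 `COc1ccc2c(c1)C(=O)OC(CO)C2` gives 250 ug/mL in this assay and that is the highest of the three numbers: compound 1 comes nearest to it, and compound 2 lies furthest away. Among the compounds with values here, the one measured step between compounds differing in a single place is a 380-fold higher number from compound 2 to compound 3 (2.58 log units; beyond the scatter) and it adds a methoxy group to the core shared by compounds 2 and 3.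

Compound 4 `COc1ccc2c(c1)C(=O)OC(CCCO)C2` keeps the methoxy group and the core of compound 3 and differs from compound 3 by a single change, 2-hydroxyethyl in place of hydroxy on a saturated chain carbon bound to a saturated ring carbon as the structures show it. Cut one bond further out, the same change reads hydroxymethyl to 3-hydroxypropyl. Within the data shown here, no measured step touches this chain, so the step from compound 2 to compound 3 tells nothing about it, and no comparison points the expectation up or down. The expectation for compound 4 is therefore a number close to that of compound 3, with no change at the digits printed from compound 3 to compound 4 (within the scatter) expected to stay within the scatter. Compound 4 is estimated at 250 ug/mL in this assay, in a range from 80 ug/mL to 800 ug/mL.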

Compound 4, concentration for 50% growth inhibition: 80.8 ug/mL
The estimate for compound 4 lay 3.1-fold (0.49 log units) above the measured number; measured number inside the range.
By their numbers in this assay, from the lowest: compound 2; then compounds 1 and 4 (each within the scatter of the next); then compound 3.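

In this assay, the chain on this saturated ring carbon proves able to shift the result: going from hydroxymethyl to 3-hydroxypropyl gives a 3.1-fold lower number from compound 3 to compound 4 (0.49 log units; beyond the scatter), a modest step towards stronger inhibition of growth. Going by these compounds alone, the only earlier step, a 380-fold higher number from compound 2 to compound 3 (2.58 log units; beyond the scatter), concerned methoxy on an aromatic carbon and said nothing about this chain, whereas here the change adds only carbon atoms and leaves the counts of hydrogen-bond donors and acceptors the same on both sides. Nothing available here accounts for the lower number with the longer chain.

A single lengthening cannot show whether the number keeps falling with a still longer chain such as 5-hydroxypentyl, or whether the hydroxy group is needed at all, which a plain propyl group, a 3-aminopropyl group or a chain ending in a carboxylic acid would help to settle. As far as these compounds go, it also remains open whether the same lengthening would give a similar step on the core of compound 2, which has hydrogen in place of the methoxy group.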